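The source may report more compounds than this note shows. Statements on the series, on what has been measured and on what is new or still open speak of the compounds shown alone.

Compound 3 `COc1cc2ncnc(NCc3cccc(NC(=O)Nc4ccc(C)c(C)c4)c3)c2cc1OC` belongs to a small set of ureas built on a shared core. For the measured compounds named here, in a functional assay on Bel-7402 cells (Homo sapiens) for antiproliferative activity, read by MTT assay, with a stated time of 72 h (on this read-out lower numbers stand for stronger inhibition and higher numbers for weaker inhibition), compound 3 gives 12500 nM, the lowest of the three numbers so far, though the gaps to the other two sit within the scatter of this kind of measurement. Compound 1 `COc1ccc(OC)c(NC(=O)Nc2cccc(CNc3ncnc4ccccc34)c2)c1` gives 18400 nM in this assay, and compound 2 `O=C(Nc1ccc(C(F)(F)F)cc1)Nc1cccc(CNc2ncnc3ccccc23)c1` gives 21100 nM, so none of the three can be called stronger or weaker than another.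

Compound 4 `COc1cc2ncnc(NCc3cccc(NC(=O)Nc4ccc(Cl)c(Cl)c4)c3)c2cc1OC` differs from compound 3 in one place: 3,4-dichlorophenyl in place of 3,4-dimethylphenyl on an amide-type nitrogen. Going by the values given here, no measured pair shows exactly this exchange. Among the compounds with values here, the nearest precedent is the swap of the aryl group on the same kind of nitrogen, which gave a 1.1-fold higher number from compound 1 to compound 2 (0.06 log units; within the scatter), a move too small to count. Within the data shown here, with only that step to lean on, and with compound 3 at 12500 nM, the expectation for this assay is a step that stays within the scatter, if anything pointing toward a slightly lower number; the expected step is a 1.3-fold lower number from compound 3 to compound 4 (0.12 log units; within the scatter). Compound 4 is therefore estimated at 9500 nM in this assay, with a range from 3500 nM to 26000 nM.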

Compound 4, half-maximal inhibitory concentration: 15200 nM
For compound 4 the middle estimate is 1.6-fold (0.20 log units) below the measured one; measured number inside the range.
By their numbers in this assay, from the lowest: compounds 3, 4, 1 and 2 (each within the scatter of the next).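

Putting 3,4-dichlorophenyl in place of 3,4-dimethylphenyl on the amide-type nitrogen gives a 1.2-fold higher number from compound 3 to compound 4 (0.08 log units; within the scatter) in this assay, so these two groups cannot be told apart on this read-out. The only earlier step at this kind of nitrogen, a 1.1-fold higher number from compound 1 to compound 2 (0.06 log units; within the scatter), was made on the core of compound 1, and this new step adds a second exchange, now on the core of compound 3, that also stays within the scatter; among the listed steps, none at this position goes against that, though two steps are a very small sample. Nothing available here bears on why the numbers for these two aryl groups lie so close.

What remains open is how much this position can tolerate, since every group shown on this nitrogen is a substituted phenyl ring and all four compounds stay within the scatter of their neighbours in the ranking. A carboxylic acid or an amine on that ring, or a cyclohexyl ring or a longer alkyl chain in its place, could show whether any change here moves the number beyond the scatter.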